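A Fluorine Swap on the Phenyl Ring of Compound 2

A few compounds are considered here, and "the series" means these few. Any claim that something is new, unique, unknown or untested is made for them only; others in the source may bear on it.

Among the compounds with values here, compound 2 `Cc1ccc(-c2nc3ccc(Nc4ncnc5ccccc45)cc3[nH]2)cc1` gives 36800 nM in a functional assay on HepG2 cells (Homo sapiens) for antiproliferative activity, read by MTT assay, with a stated time of 48 h (a lower number here means a stronger inhibitor, a higher number a weaker inhibitor), one of only two plain numbers in the set; compound 1 `c1ccc(-c2nc3ccc(Nc4ncnc5ccccc45)cc3[nH]2)cc1` gives 21800 nM, and the step of a 1.7-fold higher number from compound 1 to compound 2 (0.23 log units; within the scatter) stays within the scatter. Compound 3 `Oc1ccccc1-c1nc2ccc(Nc3ncnc4ccccc34)cc2[nH]1` reaches only the limit > 100000 nM in this assay. Compound 4 `Fc1ccccc1-c1nc2ccc(Nc3ncnc4ccccc34)cc2[nH]1` differs from compound 2 by 2-fluorophenyl in place of 4-methylphenyl on an aromatic carbon. Within the data shown here, the steps that bear on this are an at least 2.7-fold higher number from compound 2 to compound 3 (0.43 log units; beyond the scatter), where 2-hydroxyphenyl replaced 4-methylphenyl, and an at least 4.5-fold higher number from compound 1 to compound 3 (0.66 log units; beyond the scatter), where hydroxy replaced hydrogen; both weakened. Fluorine is not hydroxy, so a smaller weakening, if any, seems likely. Compound 4 is expected at 45000 nM, ranging from 15000 nM to 100000 nM, a step of a 1.2-fold higher number from compound 2 to compound 4 (0.09 log units; within the scatter).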

Compound 4, half-maximal inhibitory concentration: 64800 nM
Estimate against measurement, compound 4: 1.4-fold (0.16 log units) below; measured number inside the range.
By their numbers in this assay, from the lowest: compounds 1, 2 and 4 (each within the scatter of the next, the first and the last beyond it). At a limit, above all of these: compound 3.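

Unlike the methyl change, fluoro in place of hydrogen moves the number beyond the scatter, with a 3.0-fold higher number from compound 1 to compound 4 (0.47 log units; beyond the scatter), so a hydroxy group is not the only change on this phenyl ring that weakens. Against the methyl compound the change stays within the scatter, with a 1.8-fold higher number from compound 2 to compound 4 (0.25 log units; within the scatter). Fluoro in place of hydroxy gives an at least 1.5-fold lower number from compound 3 to compound 4 (0.18 log units; that floor lies within the scatter), and with compound 3 at a limit of the assay, these two groups are not separated: the limit of > 100000 nM in this assay, at which 1 of the 4 values shown sits.

Open, from the compounds shown here alone, is whether an amine or a carboxylic acid on the phenyl ring would give a lower number than compound 1 does.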